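This account rests on a few compounds, and the source may have more. Where it says the series, first, only, none or still open, it means among the compounds named here.

Compound 2 `COc1ccc(-c2nc(CSc3cc(C)cc(C)c3)nc3ccsc23)cn1` stands at a limit in an ADME assay on cells (Homo sapiens) for cytotoxicity, read by resazurin assay, with a stated time of 5 days; on this read-out higher numbers stand for lower toxicity in this test and lower numbers for higher toxicity in this test: compound 2 gives > 50000 nM, which is an assay limit and not a number. Compound 1 `COc1ccc(-c2nc(COc3cccc(Cl)c3)nc3ccsc23)cn1` likewise gives only a limit, > 50000 nM. Compound 3 `COc1ccc(-c2nc(CS(=O)(=O)c3cccc(Cl)c3)nc3ccsc23)cn1` also gives a limit, > 10000 nM. Every value shown here is thus a limit, two of them at the limit of > 50000 nM in this assay, at which 2 of the 3 values shown sit, and one at the limit of > 10000 nM in this assay, at which 1 of the 3 values shown sits. For the measured compounds named here, the single one-place step, a step that the two limits leave unreadable from compound 1 to compound 2, cannot be sized. Compound 4 `COc1ccc(-c2nc(CSc3cccc(Cl)c3Cl)nc3ccsc23)cn1` differs from compound 2 by 2,3-dichlorophenyl in place of 3,5-dimethylphenyl on a sulfur. Going by the values given here, no measured step bears on this change, and no value shown gives a number to move from. Compound 4 is expected to stay at the limit, estimated at 50000 nM with a range of 30000 nM to 100000 nM. The expected step, a number no higher from compound 2 to compound 4 (the limit leaves the size open), is none beyond the scatter.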

Compound 4, half-maximal cytotoxic concentration: > 50000 nM
Compound 4: only a limit was reported (the forecaster's own chance of this, stated with the estimate: 85%); the middle value sits exactly at the limit.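

Compound 4 gives > 50000 nM, a limit and not a number, and its steps from compound 1 and from compound 2 cannot be read. The compounds shown leave open whether these groups differ in cytotoxicity at all.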